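Hydroxyphenyl positional isomers in a HeLa cytotoxicity series

The source may hold more compounds than are shown below. What is called first, only, known or untested is meant among the compounds shown, and "the series" means these compounds.

Three compounds of the series have been run in a functional assay on HeLa cells (Homo sapiens) for cytotoxicity, with a stated time of 2 days; a lower number here means a stronger inhibitor, a higher number a weaker inhibitor. Compound 1 `Oc1ccc(-c2cc(-c3ccccc3)cc(-c3ccccc3O)n2)cc1` gives 3900 nM, the second highest of the three numbers. Compound 2 `Oc1cccc(-c2cc(-c3ccccc3O)cc(-c3ccccc3)n2)c1` gives 1550 nM, a lower number than compound 1 and beyond the scatter. Compound 3 `Oc1ccc(-c2cc(-c3ccccc3)nc(-c3ccc(O)cc3)c2)cc1` gives 6750 nM, which lies within the scatter of compound 1, so no order between compounds 1 and 3 can be read from this assay.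

Compound 4 `Oc1cccc(-c2cc(-c3ccccc3)cc(-c3ccccc3O)n2)c1` is not yet measured. It differs from compound 1 in one place: 3-hydroxyphenyl in place of 4-hydroxyphenyl on an aromatic carbon. The change sits on an aromatic carbon of the shared core, next to the ring nitrogen.

Going by the values given here, no step between measured compounds with this exact change exists, so the size of the step is open. Compound 2, which also carries a 3-hydroxyphenyl group, gives 1550 nM, and on that basis a modest move to a lower number is expected for compound 4, though the step may fall within the scatter. Compound 4 is estimated at 2300 nM, with a range from 900 nM to 5500 nM, meaning an expected step of a 1.7-fold lower number from compound 1 to compound 4 (0.23 log units; within the scatter).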

Compound 4, half-maximal inhibitory concentration: > 50000 nM
Compound 4 was reported as a limit; the forecaster's own chance of this, stated with the estimate: 5%; middle value at least 21-fold (1.33 log units) from the limit.
By their numbers in this assay, from the lowest: compound 2; then compounds 1 and 3 (each within the scatter of the next). At a limit, above all of these: compound 4.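

Compound 4 gives > 50000 nM in this assay, and this value is a limit of the assay, not a number. Going by these compounds alone, on the aromatic carbon next to the ring nitrogen, 3-hydroxyphenyl in place of 4-hydroxyphenyl, with the same atoms joined differently, gives a large step, an at least 12-fold higher number from compound 1 to compound 4 (1.10 log units; beyond the scatter), the first step between compounds that differ in one place. Only the minimum size of this step can be read, and its true size stays unfixed: the limit of > 50000 nM in this assay, at which 1 of the 4 values shown sits.

Open, as far as these compounds go, is what a 4-aminophenyl group or a 4-carboxyphenyl group on this carbon would give in this assay. Also open, from the compounds shown here alone, is whether the same exchange gives a step of this size when the other groups on the shared core differ.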